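The source may report more compounds than this note shows. Statements on the series, on what has been measured and on what is new or still open speak of the compounds shown alone.

Measured so far in a functional assay on SW1573 cells (Homo sapiens) for inhibition, read by sulforhodamine B assay, with a stated time of 48 h; on this read-out lower numbers stand for stronger inhibition of growth and higher numbers for weaker inhibition of growth:
Compound 1, `COC(=O)[C@@]1(C)CCC=C2[C@@H]1CC[C@@H](C)[C@]2(C)Cc1c[nH]c2ccccc12`: 7300 nM
Compound 2, `COC(=O)[C@@]1(C)CCC=C2[C@@H]1CC[C@@H](C)[C@]2(C)Cc1c[nH]c2c(Br)cccc12`: 14000 nM

Compound 2 carries the top number of the two, yet a 1.9-fold higher number from compound 1 to compound 2 (0.28 log units; within the scatter), a step that stays within the scatter of this assay, so compounds 1 and 2 cannot really be separated on these data. Compound 2 is therefore best read as a compound of roughly the same weak growth inhibition as compound 1.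

Compound 3, `COC(=O)[C@@]1(C)CCC=C2[C@@H]1CC[C@@H](C)[C@]2(C)Cc1c(C)[nH]c2c(Br)cccc12`, has not yet been measured. It differs from compound 2 in one place:
methyl in place of hydrogen on an aromatic carbon

Within the data shown here, the only measured step, a 1.9-fold higher number from compound 1 to compound 2 (0.28 log units; within the scatter), concerns bromo in place of hydrogen on an aromatic carbon and says nothing about a methyl in place of hydrogen. So no measured step bears directly on the change from compound 2 to compound 3, and the bromo step itself stayed within the scatter. With no guide pointing either way, the step expected is no change at the digits printed from compound 2 to compound 3 (within the scatter), that is, no change beyond the scatter. Compound 3 is therefore estimated to give about 14000 nM, with a likely range from 5000 nM to 40000 nM.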

Compound 3, concentration for 50% growth inhibition: 25000 nM
Estimate against measurement, compound 3: 1.8-fold (0.25 log units) below; the range from low to high includes it.
By their numbers in this assay, from the lowest: compounds 1, 2 and 3 (each within the scatter of the next, the first and the last beyond it).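

In this assay, a methyl on this aromatic carbon of the five-membered ring, next to the ring nitrogen and next to the ring atom that bears a large group, gives a 1.8-fold higher number from compound 2 to compound 3 (0.25 log units; within the scatter). Among these compounds, this is the first look at this position, since the earlier step concerned a bromo on a different aromatic carbon, and it shows that the position can carry a methyl with no difference that this assay can separate from the ordinary spread of repeated measurements. No further information is available here that could explain the result.

On these data alone, a single small group cannot show how this carbon responds in general, so it remains open whether a longer chain such as propyl, an amine or a carboxylic acid in the same place would move the number beyond the scatter, and in which direction. As far as these compounds go, it also remains open whether the methyl would give the same result on the core of compound 1, which has hydrogen in place of the bromo.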